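The compounds below may be only part of what the source reports. "The series", "measured", "known", "first", "only" and "open" are said of these compounds alone.

Working notes on the series.

Compound 3 `COc1ccc(CNC(=O)/C(C#N)=C/c2ccc(Br)o2)cc1` gives 16000 nM in a functional assay on MIA cells (Homo sapiens) for inhibition, read by MTT assay, with a stated time of 72 h; on this read-out higher numbers stand for weaker inhibition of growth and lower numbers for stronger inhibition of growth. Among the three measured compounds it stands second highest: its nearest neighbour is compound 2 `COc1ccc(CNC(=O)/C(C#N)=C/c2ccc(Cl)o2)cc1`, which gives 15000 nM, and the pair differ only by a 1.1-fold higher number from compound 2 to compound 3 (0.03 log units; within the scatter). The furthest is compound 1 `COc1ccc(CNC(=O)/C(C#N)=C/c2ccco2)cc1`, which gives 34000 nM; halogen on the furan brings a 2.3-fold lower number from compound 1 to compound 2 (0.36 log units; beyond the scatter) and a 2.1-fold lower number from compound 1 to compound 3 (0.33 log units; beyond the scatter).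

Compound 4 `COc1ccc(CNC(=O)/C(C#N)=C/c2ccc(C)cc2)cc1` is not yet measured. Its change from compound 3 is 4-methylphenyl in place of 5-bromofuran-2-yl on a double-bonded chain carbon bound to a double-bonded chain carbon: the five-membered ring with its one hetero atom and one acceptor is replaced by a six-membered ring of carbon only, with no acceptor.

For the measured compounds named here, none of the measured steps covers an exchange of the ring itself; the only steps in hand concern the halogen on the furan and the halogen pair, which add up to a modest difference. Removal of the bromo would by itself point back toward the number of compound 1, while the effect of the carbon ring is unknown in this assay, so the direction is open and the uncertainty wide. The expected step is a 1.9-fold higher number from compound 3 to compound 4 (0.27 log units; within the scatter), toward a weaker number.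

Compound 4 is therefore expected to give about 30000 nM in this assay, with a range from 10000 nM to 100000 nM.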

Compound 4, concentration for 50% growth inhibition: 38000 nM
Compound 4: the middle estimate sits 1.3-fold (0.10 log units) below what was measured; low and high end bracket the measured number.
By their numbers in this assay, from the lowest: compounds 2 and 3 (each within the scatter of the next); then compounds 1 and 4 (each within the scatter of the next).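

In this assay the ring on the double-bonded chain carbon can be exchanged outright, and 4-methylphenyl in place of a halogenated furan gives a 2.4-fold higher number from compound 3 to compound 4 (0.38 log units; beyond the scatter) and a 2.5-fold higher number from compound 2 to compound 4 (0.40 log units; beyond the scatter), both modest. Against the furan without halogen the same exchange gives a 1.1-fold higher number from compound 1 to compound 4 (0.05 log units; within the scatter), so at this position 4-methylphenyl and furan-2-yl cannot be told apart, and among the four compounds only the two carrying 5-chlorofuran-2-yl or 5-bromofuran-2-yl stand on the side of stronger inhibition of growth, though all the steps remain modest. No supporting measurement is at hand to explain these differences.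

As far as these compounds go, whether 4-chlorophenyl in place of 4-methylphenyl would bring a step like the one seen on the furan, a 2.3-fold lower number from compound 1 to compound 2 (0.36 log units; beyond the scatter), stays open. Also open is how a dimethylamino group or a carboxylic acid in place of the methyl group of compound 4 would read in this assay, since every ring shown carries only hydrogen, a halogen or methyl.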